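A few compounds are considered here, and "the series" means these few. Any claim that something is new, unique, unknown or untested is made for them only; others in the source may bear on it.

Measured so far in a functional assay on HCT-116 cells (Homo sapiens) for inhibition, read by MTT assay, with a stated time of 48 h; a lower number here means a stronger inhibitor, a higher number a weaker inhibitor:
- compound 1 `Clc1ccccc1CSc1nnc(-c2ccncc2)n1-c1ccccc1`: 13900 nM
- compound 2 `Clc1ccc(CSc2nnc(-c3ccncc3)n2-c2ccccc2)cc1`: 10700 nM

Among the compounds with values here, compound 2 stands at the smaller of the two numbers, with compound 1 as its only neighbour, but the single step of a 1.3-fold lower number from compound 1 to compound 2 (0.11 log units; within the scatter) lies within the scatter, so the two compounds are not separated by this assay. Both share the same core; they differ only in which chlorophenyl sits on the saturated chain carbon bound to the sulfur.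

Compound 3 `O=[N+]([O-])c1ccc(CSc2nnc(-c3ccncc3)n2-c2ccccc2)cc1` has not yet been measured. It differs from compound 2 by nitro in place of chloro on an aromatic carbon. Within the data shown here, no measured step exchanges a chloro for a nitro, so nothing in the two numbers above bears directly on this change; the only step available, a 1.3-fold lower number from compound 1 to compound 2 (0.11 log units; within the scatter), concerns a different exchange and is itself within the scatter. Among the measured compounds shown here, with no directional precedent, the expected step is none beyond the scatter, a 1.1-fold lower number from compound 2 to compound 3 (0.03 log units; within the scatter). Compound 3 is therefore estimated at 10000 nM in this assay, with a range from 3500 nM to 30000 nM allowing for the untested nature of the exchange.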

Compound 3, half-maximal inhibitory concentration: 23800 nM
Beside the measured number, compound 3's estimate is 2.4-fold (0.38 log units) below it, within the range that was stated.
By their numbers in this assay, from the lowest: compounds 2, 1 and 3 (each within the scatter of the next, the first and the last beyond it).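

In this assay, within the data shown here, the exchange of chloro for nitro on an aromatic carbon para to a large group gives a 2.2-fold higher number from compound 2 to compound 3 (0.35 log units; beyond the scatter) and is the first step to pass the scatter, though only modestly. This position therefore responds to the group placed on it, which the earlier pair could not show, as that pair differed only in where the chloro stood on the phenyl ring. The effect holds only against the 4-chlorophenyl partner: the wider exchange of 2-chlorophenyl for 4-nitrophenyl gives a 1.7-fold higher number from compound 1 to compound 3 (0.23 log units; within the scatter) and leaves that pair unseparated, and no measurement at hand accounts for the step.

Open, as far as these compounds go, is whether this step belongs to nitro in particular or would also appear with another group on the same aromatic carbon, such as an amine, a carboxylic acid or a methoxy group. Also open, from the compounds shown here alone, is whether the chloro-to-nitro exchange would give a similar step with a longer chain in place of the single saturated carbon bound to the sulfur.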